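The compounds below may be only part of what the source reports. "The series", "measured", "known", "first", "only" and "open" are said of these compounds alone.

Values in an ADME assay on CEM-SS cells (Homo sapiens) for cytotoxicity, read by XTT assay (on this read-out lower numbers stand for higher toxicity in this test and higher numbers for lower toxicity in this test), so far:
- Compound 1 `CN(O)C(=O)c1cc2ccn(Cc3ccc(F)cc3F)c2cn1` gives 200000 nM
- Compound 2 `COCCOCc1cn(Cc2ccc(F)cc2)c2cnc(C(=O)N(C)O)cc12` gives > 100000 nM, which is a limit
- Compound 3 `COCc1cn(Cc2ccc(F)cc2)c2cnc(C(=O)N(C)O)cc12` gives 266000 nM

Compound 3 lies within the scatter of compound 1, so the two cannot be ranked. Compound 4 `COCCOCCCc1cn(Cc2ccc(F)cc2)c2cnc(C(=O)N(C)O)cc12` differs from compound 3 (2-(2-methoxyethoxy)ethyl in place of methoxy on a saturated chain carbon bound to an aromatic carbon), with 2-(2-methoxyethoxy)ethyl in place of methoxy on a saturated chain carbon bound to an aromatic carbon. Within the data shown here, only one measured step bears on this change: a step that the limit leaves unreadable from compound 2 to compound 3. Compound 2 sits at the limit of > 100000 nM in this assay, at which 1 of the 3 values shown sits, so that step gives no size and no direction. With nothing measured to suggest a shift, the expected 1.3-fold lower number from compound 3 to compound 4 (0.12 log units; within the scatter) stays within the scatter. In this assay the estimate for compound 4 is 200000 nM, with an expected range from 80000 nM to 400000 nM.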

Compound 4, half-maximal cytotoxic concentration: > 10000 nM
Compound 4 was reported as a limit; the forecaster's own chance of this, stated with the estimate: 45%; the middle value lies beyond the limit too.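

Compound 4 gives > 10000 nM in this assay, which is a limit, so its steps from compound 2 and compound 3 cannot be read. The compounds shown leave open whether 2-(2-methoxyethoxy)ethyl in place of methoxy changes the half-maximal cytotoxic concentration at all.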